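This account rests on a few compounds, and the source may have more. Where it says the series, first, only, none or still open, it means among the compounds named here.

Measured so far:
compound 1 `COc1ccc(/C(Cl)=C/C=C(\C#N)C(=O)c2c[nH]c3ccc(Br)cc23)cc1`, 15.6%;
compound 2 `COc1ccc2[nH]cc(C(=O)/C(C#N)=C/C=C(\Cl)c3ccc(Br)cc3)c2c1`, 40.8%;
compound 3 `N#C/C(=C\C=C(/Cl)c1ccc(Br)cc1)C(=O)c1c[nH]c2ccccc12`, 18.4%.

In a functional assay for inhibition, with a stated time of 30 min, tested at 1 mM (a lower number here means less inhibition, a higher number more inhibition at the concentration tested (going by the name of the read-out)), compound 3 stands second highest of the three numbers. Its nearest neighbour is compound 1, which gives 15.6%, a gap within the scatter; the furthest is compound 2, reached by the step of a number 22.4 percentage points lower from compound 2 to compound 3 (beyond the scatter), where hydrogen replaced methoxy on an aromatic carbon. Compound 4 `N#C/C(=C\C=C(/Cl)c1ccc(Br)cc1)C(=O)c1c[nH]c2ccc(Br)cc12` differs from compound 3 by bromo in place of hydrogen on an aromatic carbon. Going by the values given here, no measured step shows bromo in place of hydrogen at this place, so the only guide is that compound 3 and compound 1 give numbers within the scatter of each other. The step of a number 1.6 percentage points higher from compound 3 to compound 4 (within the scatter) is therefore expected to be small, likely within the scatter. Compound 4 is estimated to give 20%, between 8% and 35%.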

Compound 4, a percentage reported as inhibition, at one concentration (the size of the read-out at that concentration, not a potency): 15.8%
Compound 4: middle estimate off by 4.2 percentage points, on the high side; the range from low to high includes it.
By their numbers in this assay, from the lowest: compounds 1, 4 and 3 (each within the scatter of the next); then compound 2.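

In this assay, placing bromo on this carbon of the fused ring system gives a step within the scatter (a number 2.6 percentage points lower from compound 3 to compound 4 (within the scatter)), so bromo and hydrogen cannot be told apart here. Replacing methoxy at the same carbon gives a clear step (a number 25 percentage points lower from compound 2 to compound 4 (beyond the scatter)), so among these three groups only methoxy stands apart. Going by these compounds alone, the same exchange at a different aromatic carbon gives no such step (a number 0.2 percentage points higher from compound 1 to compound 4 (within the scatter)), so the methoxy result holds only for that one place.

Nothing available explains these numbers. As far as these compounds go, whether an amine or a carboxylic acid on this carbon would match methoxy or hydrogen remains open.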